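This account rests on a few compounds, and the source may have more. Where it says the series, first, only, none or still open, it means among the compounds named here.

In an assay on MCF7 cells for inhibition of Serine-protein kinase ATM (Homo sapiens), read by immunofluorescence, with a stated time of 1 h (on this read-out lower numbers stand for stronger inhibition and higher numbers for weaker inhibition), compound 3, `COCCOc1cc2c(-n3nc(-c4ccccn4)nc3N)ncnc2cc1OC`, gives 1200 nM, the lowest of the two numbers measured in the series. Compound 2, `COc1cc2ncnc(-n3nc(-c4ccccn4)nc3N)c2cc1OCc1ccccc1`, gives 8600 nM. Compound 1, `COc1cc2ncnc(-n3nc(-c4ccccn4)nc3N)c2cc1N`, reaches only the assay limit > 40000 nM, as recorded in the limit of > 40000 nM in this assay, at which 1 of the 3 values shown sits. Two steps favour compound 3: an at least 33-fold lower number from compound 1 to compound 3 (1.52 log units; beyond the scatter), and a 7.2-fold lower number from compound 2 to compound 3 (0.86 log units; beyond the scatter). Compound 4, `COc1cc2ncnc(-n3nc(-c4ccccn4)nc3N)c2cc1OCCNC(=O)OC(C)(C)C`, carries the change ((tert-butoxycarbonyl)amino in place of methoxy on a saturated chain carbon, two bonds along the chain from an oxygen on an aromatic ring). The step that bears on it is the exchange at the chain end, a 7.2-fold lower number from compound 2 to compound 3 (0.86 log units; beyond the scatter), where a longer substituent on this oxygen gave the higher number. The expectation for compound 4 is therefore a weakening in this assay, a 2.5-fold higher number from compound 3 to compound 4 (0.40 log units; beyond the scatter), smaller than that step since the ether oxygen is kept. Compound 4 is estimated at 3000 nM, expected between 1000 nM and 10000 nM.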

Compound 4, half-maximal inhibitory concentration: 800 nM
For compound 4 the middle estimate is 3.8-fold (0.57 log units) above the measured one; the measured number lies below the stated range.
By their numbers in this assay, from the lowest: compounds 4 and 3 (each within the scatter of the next); then compound 2. At a limit, above all of these: compound 1.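

In this assay, (tert-butoxycarbonyl)amino in place of methoxy at the chain end gives a 1.5-fold lower number from compound 3 to compound 4 (0.18 log units; within the scatter), so this much larger end group, which adds a hydrogen-bond donor, does not separate compound 4 from compound 3. The phenyl end of compound 2 does stand apart, with an 11-fold lower number from compound 2 to compound 4 (1.03 log units; beyond the scatter), so the size of the group on this oxygen does not alone set the number. The remaining step, an at least 50-fold lower number from compound 1 to compound 4 (1.69 log units; beyond the scatter), is counted from a limit: the limit of > 40000 nM in this assay, at which 1 of the 4 values shown sits.

Open, going by these compounds, is whether a free primary amine or a carboxylic acid at the chain end would stay level with compound 3 and compound 4. On these data alone, a longer chain carrying the same carbamate also remains open.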